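Replacing an arylamine with pyrrolidine on the shared core

A few compounds are considered here, and "the series" means these few. Any claim that something is new, unique, unknown or untested is made for them only; others in the source may bear on it.

Compound 2 `CCc1ccc(NC2=CC(=O)c3nc4n(c3C2=O)[C@H]2OC[C@@H](O)[C@H]2OC4)cc1` holds the lowest of the two plain numbers in a functional assay on HeLa cells (Homo sapiens) for inhibition, read by sulforhodamine B assay (a higher number here means a weaker inhibitor, a lower number a stronger inhibitor), where compound 2 gives 3990 nM. Its nearest neighbour is compound 1 `CCCc1ccc(NC2=CC(=O)c3c(nc4n3[C@H]3OC[C@@H](O)[C@H]3OC4)C2=O)cc1`, which in this assay gives 6030 nM, a gap within the scatter, so no order between the two can be claimed. Compound 3 `O=C1C(Nc2cccc(F)c2)=CC(=O)c2c1nc1n2[C@H]2OC[C@@H](O)[C@H]2OC1` reaches only a limit of this assay, > 8000 nM, and not a number. Among the measured compounds shown here, the one measured step, an at least 1.3-fold higher number from compound 1 to compound 3 (0.12 log units; that floor lies within the scatter), shows that exchanging one aryl group for another can push a compound to the limit (the limit of > 8000 nM in this assay, at which 1 of the 3 values shown sits).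

Compound 4 `O=C1C=C(N2CCCC2)C(=O)c2c1nc1n2[C@H]2OC[C@@H](O)[C@H]2OC1` differs from compound 2 by pyrrolidin-1-yl in place of (4-ethylphenyl)amino on a double-bonded ring carbon. For the measured compounds named here, no measured step exchanges the aromatic ring and its amine for a saturated ring, so the one step offers only indirect guidance. The account therefore expects a higher number, a 2.3-fold higher number from compound 2 to compound 4 (0.35 log units; beyond the scatter), with a real chance of a limit. For compound 4 the estimate in this assay is 9000 nM, within a range from 3000 nM to 30000 nM.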

Compound 4, half-maximal inhibitory concentration: > 16000 nM
Compound 4 ended at the assay's limit; the forecaster's own chance of this, stated with the estimate: 50%; middle value at least 1.7-fold (0.24 log units) away from the limit.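

In this assay, the exchange on this double-bonded ring carbon gives an at least 4.0-fold higher number from compound 2 to compound 4 (0.60 log units; beyond the scatter). Among the compounds shown, this is the first step that clearly lies beyond the scatter, whereas swapping one arylamine for another gave an at least 1.3-fold higher number from compound 1 to compound 3 (0.12 log units; that floor lies within the scatter). Compound 4 reaches a limit of this assay and not a number, so its step gives only a floor: the limit of > 16000 nM in this assay, at which 1 of the 4 values shown sits.

The change removes the six-membered aromatic ring and the hydrogen-bond donor together, which leaves open which of the two loses the activity, and how far the pyrrolidin-1-yl group alone accounts for the step. A cyclopentylamino group, which keeps the amine hydrogen on a saturated ring, and a methyl(phenyl)amino group, which keeps the aromatic ring without that hydrogen, would separate the two.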